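The source may hold more compounds than are shown below. What is called first, only, known or untested is meant among the compounds shown, and "the series" means these compounds.

Working notes on the series. For the measured compounds named here, in an ADME assay on C8166 cells (Homo sapiens) for cytotoxicity, read by MTT assay (on this read-out higher numbers stand for lower toxicity in this test and lower numbers for higher toxicity in this test), compound 3 `Cc1cc(S(N)(=O)=O)ccc1NC(=O)COc1ccc(F)cc1Oc1ccc2ccccc2c1C` gives 56100 nM, one of only two plain numbers in hand; compound 1 `Cc1cc(S(N)(=O)=O)ccc1NC(=O)COc1ccc(F)cc1Oc1cccc2ccccc12` gives 33100 nM, and the gap between them is a 1.7-fold higher number from compound 1 to compound 3 (0.23 log units; within the scatter). Compound 2 `Cc1cc(S(N)(=O)=O)ccc1NC(=O)COc1ccc(F)cc1Oc1ccc2cc(Br)ccc2c1` reaches only an assay limit, > 357000 nM, so the limit of > 357000 nM in this assay, at which 1 of the 3 values shown sits, applies to it. Compound 4 `Cc1cc(S(N)(=O)=O)ccc1NC(=O)COc1ccc(F)cc1Oc1ccc2ccccc2c1Br` differs from compound 3 by bromo in place of methyl on an aromatic carbon. Going by the values given here, the steps that bear on this are an at least 6.3-fold lower number from compound 2 to compound 3 (0.80 log units; beyond the scatter) and an at least 10-fold higher number from compound 1 to compound 2 (1.03 log units; beyond the scatter), both involving a bromo-bearing naphthyl, though neither places the bromo where compound 4 carries it. A step of a 2.0-fold higher number from compound 3 to compound 4 (0.29 log units; within the scatter) is therefore expected, towards a higher number, with wide uncertainty. Compound 4 is estimated at 110000 nM, within a range from 35000 nM to 357000 nM.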

Compound 4, half-maximal cytotoxic concentration: 39500 nM
Estimate against measurement, compound 4: 2.8-fold (0.44 log units) above; measured number inside the range.
By their numbers in this assay, from the lowest: compounds 1, 4 and 3 (each within the scatter of the next). At a limit, above all of these: compound 2.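

In this assay, bromo in place of methyl on this aromatic carbon gives a 1.4-fold lower number from compound 3 to compound 4 (0.15 log units; within the scatter), and 1-bromonaphthalen-2-yl in place of naphthalen-1-yl gives a 1.2-fold higher number from compound 1 to compound 4 (0.08 log units; within the scatter), so neither change separates these compounds. Bromo alone therefore does not carry the high number of compound 2, since 1-bromonaphthalen-2-yl in place of 6-bromonaphthalen-2-yl gives an at least 9.0-fold lower number from compound 2 to compound 4 (0.95 log units; beyond the scatter). The value of compound 2 in that step is an assay limit: the limit of > 357000 nM in this assay, at which 1 of the 4 values shown sits.

Open, from the compounds shown here alone, is whether an amine or a carboxylic acid on this aromatic carbon would stay level with methyl and bromo. Also open, going by these compounds, is how far the number of compound 2 lies beyond its limit.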